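Swapping the aryl group on the sulfonyl sulfur

This account rests on a few compounds, and the source may have more. Where it says the series, first, only, none or still open, it means among the compounds named here.

Measured compounds:
compound 1 `COc1ccc(S(=O)(=O)c2cnc3c(F)cccc3c2N2CCC(C)CC2)cc1`, 67%
compound 2 `COc1ccc2ncc(S(=O)(=O)c3ccc(C)c(F)c3)c(N3CCC(C)CC3)c2c1`, 73%
compound 3 `CC1CCN(c2c(S(=O)(=O)c3cc(Cl)cc(Cl)c3)cnc3cc(Cl)ccc23)CC1`, 93%

Three compounds were measured in an assay on isolated protein for displacement of a labelled ligand from metabotropic glutamate receptor 5 (Homo sapiens), with a stated time of 60 min, tested at 1 uM; on this read-out higher numbers stand for more inhibition at the one concentration tested (going by the name of the read-out) and lower numbers for less inhibition. Compound 1 gives the lowest of the three numbers, at 67%. Compound 2 sits nearest to it, with a number that lies within the scatter of repeated measurements, so the two cannot be told apart. Compound 3, at 93%, lies furthest from compound 1, and that gap is beyond the scatter; compound 3 differs from compound 1 in more than one place, so no single cause can be read from it.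

Compound 4 `CC1CCN(c2c(S(=O)(=O)c3ccc(F)c(F)c3)cnc3c(F)cccc23)CC1` has not been measured. It differs from compound 1 in one place: 3,4-difluorophenyl in place of 4-methoxyphenyl on a sulfonyl sulfur. Among the compounds with values here, no single-change step between measured compounds is available to calibrate this swap. The only halogen-bearing aryl on the sulfonyl, in compound 3, goes with the highest number, but that compound also carries other changes. A small rise is expected for compound 4, a number 10 percentage points higher from compound 1 to compound 4 (within the scatter), most likely within or just beyond the scatter. Compound 4 is estimated at 77%, with a range from 60% to 92%.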

Compound 4, a percentage reported as inhibition, at one concentration (the size of the read-out at that concentration, not a potency): 93%
Estimate against measurement, compound 4: 16 percentage points below; the measured number lies above the stated range.
By their numbers in this assay, from the lowest: compounds 1 and 2 (each within the scatter of the next); then compounds 3 and 4 (each within the scatter of the next).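

In this assay, within the data shown here, 3,4-difluorophenyl in place of 4-methoxyphenyl on a sulfonyl sulfur gives a number 26 percentage points higher from compound 1 to compound 4 (beyond the scatter), the first step in which this group alone changes. It shows that the aryl group at this place can by itself move the read-out beyond the scatter, with the rest of compound 1 left as it stands, although the two groups match in heavy-atom count and each holds one six-membered aromatic ring of carbon only. Nothing measured here says why this swap goes with the higher number.

The compounds shown leave open whether both fluorines are needed, since 4-fluorophenyl and plain phenyl do not appear on this sulfur. They also leave open how a pyridyl ring or a small alkyl group would read at this place.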